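The source may hold more compounds than are shown below. What is called first, only, known or untested is meant among the compounds shown, and "the series" means these compounds.

Compound 2, with the structure `O=C1C(=O)N(CCCCn2cc(COc3cc(=O)oc4ccccc34)nn2)c2ccccc21`, and compound 3, with the structure `O=C1C(=O)N(CCCCCn2cc(COc3cc(=O)oc4ccccc34)nn2)c2ccccc21`, share the same core and differ in the chain that joins its two ring systems; the difference between the two cores is not broken down here. Compound 1, with the structure `COc1ccc2c(c1)C(=O)C(=O)N2CCCCn1cc(COc2cc(=O)oc3ccccc23)nn1`, carries a methoxy group on the core of compound 2, and compound 4, with the structure `COc1ccc2c(c1)C(=O)C(=O)N2CCCCCn1cc(COc2cc(=O)oc3ccccc23)nn1`, carries the same group on the core of compound 3.

In a functional assay on THP-1 cells (Homo sapiens) for inhibition, read by sulforhodamine B assay, with a stated time of 48 h, tested at 50 uM (a lower number here means less inhibition of growth, a higher number more inhibition of growth at the concentration tested), compound 2 gives 85%. In this assay compound 3 gives 69%, and compound 1 gives 52%. For the measured compounds named here, the one change made twice is methoxy in place of hydrogen on an aromatic carbon, which appears again as methoxy in place of hydrogen on an aromatic carbon; the two "place" descriptions agree word for word, so it is the same kind of change on two cores. From the measured pair it made a step of a number 33 percentage points lower from compound 2 to compound 1 (beyond the scatter).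

Because a number 33 percentage points lower from compound 2 to compound 1 (beyond the scatter) is large and beyond the scatter, the same change on the core of compound 3 is expected to make a step of about a number 31 percentage points lower from compound 3 to compound 4 (beyond the scatter). Compound 4 is therefore estimated at 38%, expected to fall between 22% and 54%. This rests on a single measured step, so the spread is kept wide.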

Compound 4, percent growth inhibition at one concentration: 30%
Estimate against measurement, compound 4: 8 percentage points above; the measured number falls inside the stated range.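

In this assay, methoxy in place of hydrogen on an aromatic carbon again lowers growth inhibition on the second core, with a number 39 percentage points lower from compound 3 to compound 4 (beyond the scatter). Set side by side, the two steps agree in direction and in size, so in these four compounds the change carries over from the core of compound 2 to the core of compound 3, two cores that differ in the chain joining their ring systems: the same change on two cores in this assay, a number 33 percentage points lower (beyond the scatter) from compound 2 to compound 1 and a number 39 percentage points lower (beyond the scatter) from compound 3 to compound 4, 6 percentage points apart, within the scatter of two such steps. This agreement rests on just two pairs, one place on the ring and one read-out at a single concentration, so it does not show that the step would hold on a core differing in some other way, and it does not explain why methoxy lowers the number.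

The compounds shown leave open whether a hydroxyl group, a chlorine atom or a methyl group at the same place would lower the number as methoxy does, and whether methoxy on another aromatic carbon of that ring would give a step of similar size. They also leave open whether the step would persist with a longer chain than that of compound 3, or with a chain holding an amine.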